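Indole for benzofuran on the carbonyl of compound 1

The source may report more compounds than this note shows. Statements on the series, on what has been measured and on what is new or still open speak of the compounds shown alone.

In an ADME assay on microsomes from liver (Homo sapiens) for metabolic stability, with a stated time of 30 min, tested at 1 uM (on this read-out higher numbers stand for a longer-lived compound and lower numbers for a shorter-lived compound), compound 1 `COc1cccc(CN2C(=O)CN(C(=O)c3cc4cc(OC)ccc4o3)C[C@@H]2CCc2ccccc2)c1` gives 0.128 h. Compound 3 `O=C(c1cc2cc(C3CC3)ccc2[nH]1)N1CC(=O)N(Cc2ccccc2)[C@@H](CN2CCC(F)CC2)C1` gives 0.383 h in this assay, and compound 2 `COc1ccc2[nH]c(C(=O)N3CC(=O)N(Cc4ccccc4)[C@@H](CN4CCC5(CC4)CC5)C3)cc2c1` gives 0.867 h; compound 1 thus has the lowest number of the three, and its gap to each of the other two lies beyond the scatter. Compounds 2 and 3 both carry an indol-2-yl group on the carbonyl where compound 1 carries a benzofuran-2-yl, but they also differ from compound 1 in several further places, so no single step can be read from them.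

Compound 4 `COc1cccc(CN2C(=O)CN(C(=O)c3cc4cc(OC)ccc4[nH]3)C[C@@H]2CCc2ccccc2)c1` has not been measured; it differs from compound 1 by 5-methoxy-1H-indol-2-yl in place of 5-methoxy-1-benzofuran-2-yl on a carbonyl carbon. Within the data shown here, the only guide is that both indole-bearing compounds sit higher than compound 1 in this assay while differing elsewhere, so the step is expected to be an increase of a size close to the scatter: a 2.0-fold higher number from compound 1 to compound 4 (0.29 log units; within the scatter). Compound 4 is estimated at 0.25 h in this assay, within a range from 0.1 h to 0.6 h.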

Compound 4, half-life: 0.12 h
Compound 4: the middle estimate sits 2.1-fold (0.32 log units) above what was measured; the measured number falls inside the stated range.
By their numbers in this assay, from the lowest: compounds 4 and 1 (each within the scatter of the next); then compound 3; then compound 2.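

With the rest of compound 1 held fixed, 5-methoxy-1H-indol-2-yl in place of 5-methoxy-1-benzofuran-2-yl on the carbonyl carbon gives a 1.1-fold lower number from compound 1 to compound 4 (0.03 log units; within the scatter) in this assay. Among these compounds, this is the first reading of this change on its own, and it does not separate the two groups on this core, even though the entering group brings a hydrogen-bond donor that the leaving group lacks. Nothing at hand bears on why the two groups read alike.

As far as these compounds go, it remains open whether the same exchange would read alike on the cores of compound 2 and compound 3. From the compounds shown here alone, it is also open whether a different group on this carbonyl carbon, such as a pyridine or a simple phenyl, would shift the half-life beyond the scatter.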